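Cytotoxicity of the series sits at the assay limit

This account rests on a few compounds, and the source may have more. Where it says the series, first, only, none or still open, it means among the compounds named here.

Compound 1 `CC1CCN(C2CCN(S(=O)(=O)c3ccc(C#N)cc3)CC2)CC1` carries the 4-cyanophenyl group on the sulfonyl sulfur. In an ADME assay on HCT-116 cells (Homo sapiens) for cytotoxicity, read by CellTiter-Glo, with a stated time of 72 h (on this read-out lower numbers stand for stronger inhibition and higher numbers for weaker inhibition), compound 1 gives > 5000 nM, which is a limit of the assay and not a number. Compound 2 `COc1ccccc1-c1ccc(S(=O)(=O)N2CCC(N3CCC(C)CC3)CC2)cc1` likewise returns a limit, > 5000 nM. Compound 3 `CC1CCN(C2CCN(S(=O)(=O)c3ccc(OCc4ccccc4)cc3)CC2)CC1` also returns a limit, > 5000 nM. The steps a step that the two limits leave unreadable from compound 1 to compound 2, a step that the two limits leave unreadable from compound 1 to compound 3 and a step that the two limits leave unreadable from compound 2 to compound 3 therefore cannot be sized; all that the three values show is the limit of > 5000 nM in this assay, at which 3 of the 3 values shown sit. Compound 4 `CC1CCN(C2CCN(S(=O)(=O)c3ccc(Cl)c(Cl)c3)CC2)CC1` differs from compound 1 by 3,4-dichlorophenyl in place of 4-cyanophenyl on a sulfonyl sulfur. Going by the values given here, no measured step gives the size of such a change. Compound 4 is expected to remain at the same limit, with an estimated step that the limit leaves unreadable from compound 1 to compound 4. The estimate for compound 4 is 8000 nM, within 3000 nM to 30000 nM.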

Compound 4, half-maximal inhibitory concentration: > 5000 nM
Compound 4 ended at the assay's limit; the forecaster's own chance of this, stated with the estimate: 80%; the middle value is on the limit's open side.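

Compound 1 and compound 4 both sit at a limit, not a number, so the change between them cannot be sized: the limit of > 5000 nM in this assay, at which 4 of the 4 values shown sit.

The compounds shown leave open whether any group on the sulfonyl sulfur gives a measurable value in this assay.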